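The source may hold more compounds than are shown below. What is called first, only, known or untested is meant among the compounds shown, and "the series" means these compounds.

Measured in a functional assay on A549 cells (Homo sapiens) for cytotoxicity, read by MTT assay, with a stated time of 72 h; a lower number here means a stronger inhibitor, a higher number a weaker inhibitor:
- compound 1 `Nc1cccc(Nc2nc3ccccc3nc2S(=O)(=O)c2ccccc2)c1` gives 1590 nM
- compound 2 `COc1ccc(S(=O)(=O)c2nc3ccccc3nc2Nc2ccccc2)cc1` gives 13200 nM
- compound 3 `COc1ccc(Nc2nc3ccccc3nc2S(=O)(=O)c2ccc(OC)cc2)cc1` gives 8260 nM

Compound 3 at 8260 nM lies within the scatter of compound 2 at 13200 nM and carries a clearly higher number than compound 1 at 1590 nM.

Next is compound 4 `COc1ccc(S(=O)(=O)c2nc3ccccc3nc2Nc2cccc(N)c2)cc1`, not yet measured. The change from compound 3 is 3-aminophenyl in place of 4-methoxyphenyl on a nitrogen on an aromatic ring, in words 3-aminophenyl in place of 4-methoxyphenyl on a nitrogen on an aromatic ring. The other 4-methoxyphenyl of compound 3 stays.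

Within the data shown here, only one measured step changes the group on that nitrogen alone: a 1.6-fold lower number from compound 2 to compound 3 (0.20 log units; within the scatter). It replaces hydrogen with methoxy, and being within the scatter, it gives little guide to the size of the coming step. Among the measured compounds shown here, the better clue is compound 1 at 1590 nM, the only measured compound bearing 3-aminophenyl, although no measured step isolates that group and compound 1 lacks the methoxy that compound 4 keeps. A lower number is therefore expected in this assay, with some of the gap to compound 1 possibly left open. The expected change is a 3.3-fold lower number from compound 3 to compound 4 (0.52 log units; beyond the scatter), an estimate with wide uncertainty. Compound 4 is estimated at 2500 nM, with an expected range of 900 nM to 7000 nM.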

Compound 4, half-maximal inhibitory concentration: 340 nM
The estimate for compound 4 lay 7.4-fold (0.87 log units) above the measured number, outside the stated range (below it).
By their numbers in this assay, from the lowest: compound 4; then compound 1; then compounds 3 and 2 (each within the scatter of the next).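

In this assay, among these compounds, this is the first large step at the nitrogen on the aromatic ring: a 24-fold lower number from compound 3 to compound 4 (1.39 log units; beyond the scatter). Among the compounds shown here, with the other 4-methoxyphenyl held constant, adding the amino group alone gives a 39-fold lower number from compound 2 to compound 4 (1.59 log units; beyond the scatter), so the amino group now has its own measured step, which the earlier compounds did not provide. Methoxy in place of hydrogen on an aromatic carbon also proves to depend on its setting, giving a 4.7-fold lower number from compound 1 to compound 4 (0.67 log units; beyond the scatter) and not merely a change within the scatter: the same change on two cores in this assay, a 1.6-fold lower number (0.20 log units; within the scatter) from compound 2 to compound 3 and a 4.7-fold lower number (0.67 log units; beyond the scatter) from compound 1 to compound 4, 2.9-fold (0.47 log units) apart, beyond the scatter of two such steps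

The compounds shown leave open whether the lower number requires the amino group specifically, as a hydroxyl, an acetamide or a dimethylamino group on the same phenyl would test that directly. For the compounds shown here, they also do not separate the effect of the amino group from that of its location on the ring, and they show only one aromatic group carrying it, so how far this step carries over to other substituents on the shared core remains unknown.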